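Thiophen-2-yl in place of 4-methoxyphenyl: series notes

This account rests on a few compounds, and the source may have more. Where it says the series, first, only, none or still open, it means among the compounds named here.

In a functional assay on KB-VIN10 cells (Homo sapiens) for inhibition, with a stated time of 72 h (on this read-out higher numbers stand for weaker inhibition and lower numbers for stronger inhibition), compound 2 `COc1ccc(-c2cccc3c2N(S(=O)(=O)c2ccc(OC)cc2)CC3)cc1` gives 352 nM. Compound 1 `COc1ccc(S(=O)(=O)N2CCc3cccc(-c4ccc(N)cc4)c32)cc1` gives 262 nM, and compound 3 `COc1ccc(S(=O)(=O)n2ccc3cccc(-c4ccc(F)cc4)c32)cc1` gives 202 nM, so the three values lie within the scatter of one another. Compound 4 `COc1ccc(S(=O)(=O)N2CCc3cccc(-c4cccs4)c32)cc1` differs from compound 2 by thiophen-2-yl in place of 4-methoxyphenyl on an aromatic carbon. Going by the values given here, the only measured step, a 1.3-fold higher number from compound 1 to compound 2 (0.13 log units; within the scatter), stays within the scatter, but it keeps the aromatic group that is exchanged here. Among the compounds with values here, compound 3 has a different core and gives no direct step, so the evidence is indirect. No change beyond the scatter is expected in this assay. The expected step is a 1.2-fold lower number from compound 2 to compound 4 (0.07 log units; within the scatter). For compound 4 the estimated value is 300 nM, with an expected range of 110 nM to 800 nM.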

Compound 4, half-maximal inhibitory concentration: 251 nM
Compound 4: the middle estimate sits 1.2-fold (0.08 log units) above what was measured; the measured number falls inside the stated range.
By their numbers in this assay, from the lowest: compounds 3, 4, 1 and 2 (each within the scatter of the next).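

In this assay, the exchange of a six-membered aromatic ring of carbon only for a five-membered aromatic ring with 1 hetero atom stays within the scatter (a 1.4-fold lower number from compound 2 to compound 4 (0.15 log units; within the scatter)). The same holds against the amino-bearing ring (a 1.0-fold lower number from compound 1 to compound 4 (0.02 log units; within the scatter)), so this aromatic carbon of the shared core now carries three different aromatic groups with no change beyond the scatter. Nothing available bears on the reason for this. Still open, as far as these compounds go, is whether a non-aromatic group at this position, such as morpholine, or a phenyl ring carrying a carboxylic acid, would also stay within the scatter.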